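Alpha-ketooxazole inhibitors: swapping an aryl group for an ester chain

A few compounds are considered here, and "the series" means these few. Any claim that something is new, unique, unknown or untested is made for them only; others in the source may bear on it.

Measured compounds:
compound 1 `O=Cc1ccc(-c2cnc(C(=O)CCCCCCc3ccccc3)o2)nc1`: 2.2 nM
compound 2 `O=C(CCCCCCc1ccccc1)c1ncc(-c2ccc(CCl)cn2)o1`: 22.4 nM

In an assay for inhibition of Fatty-acid amide hydrolase 1 (Rattus norvegicus), using a Dixon plot (on this read-out lower numbers stand for stronger inhibition and higher numbers for weaker inhibition), compound 1 gives 2.2 nM. Compound 2 gives 22.4 nM in this assay, which is the highest of the two numbers; its nearest neighbour is compound 1, and the step of a 10-fold higher number from compound 1 to compound 2 (1.01 log units; beyond the scatter) arose from chloromethyl in place of formyl on an aromatic carbon.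

Compound 3 `COC(=O)CCCCc1cnc(C(=O)CCCCCCc2ccccc2)o1` has not been measured. It differs from compound 2 by a group of 8 heavy atoms (6 carbon, 2 oxygen; no ring) in place of a group of 8 heavy atoms (6 carbon, 1 nitrogen, 1 chlorine; one six-membered aromatic ring with 1 hetero atom), on an aromatic carbon. Among the compounds with values here, the only measured step, a 10-fold higher number from compound 1 to compound 2 (1.01 log units; beyond the scatter), concerns a change of a small substituent on the six-membered ring, whereas the step to compound 3 removes that ring altogether and puts a 4-(methoxycarbonyl)butyl chain in its place, so it bears on the new step only loosely: it shows that this part of the molecule is sensitive to change. Within the data shown here, with no direct precedent, a step of considerable size in this assay is expected, most likely towards a higher number. Compound 3 is therefore estimated at 150 nM, within 20 nM to 1500 nM, corresponding to an expected step of a 6.7-fold higher number from compound 2 to compound 3 (0.83 log units; beyond the scatter).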

Compound 3, inhibition constant: 1.8 nM
Compound 3: middle estimate off by 83-fold (1.92 log units), on the high side; the measured number lies below the stated range.
By their numbers in this assay, from the lowest: compounds 3 and 1 (each within the scatter of the next); then compound 2.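

In this assay, the six-membered aromatic ring proves not to be required on the aromatic carbon next to the ring oxygen: replacing the ring of compound 2 with the ring-free 4-(methoxycarbonyl)butyl chain gives a 12-fold lower number from compound 2 to compound 3 (1.09 log units; beyond the scatter). The same chain in place of the formyl-bearing ring of compound 1 gives a 1.2-fold lower number from compound 1 to compound 3 (0.09 log units; within the scatter), so on this read-out this flexible ester chain and that ring-bearing group cannot be told apart. The earlier compounds shown here varied only a small substituent on the ring, so the sensitivity they showed belongs to that substituent and does not amount to a need for the ring itself.

It remains open whether the ester matters at all, since the compounds shown do not tell what a plain alkyl chain, a carboxylic acid or an amide at the chain end, or a shorter or longer chain would give. They also leave open how other substituents on the six-membered ring, such as an amine or a hydroxymethyl group, would compare with formyl and chloromethyl. No measurement at hand accounts for the behaviour of the chain at this position.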